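The source may hold more compounds than are shown below. What is called first, only, known or untested is meant among the compounds shown, and "the series" means these compounds.

Measured compounds:
compound 1, `COc1ccc(-c2cc(/C=C/C(=O)c3ccc(N)cc3)[nH]n2)cc1`, 90%
compound 2, `COc1cc(-c2cc(/C=C/C(=O)c3ccc(Cl)c(Cl)c3)[nH]n2)cc(OC)c1OC`, 73%
compound 3, `COc1ccc(C(=O)/C=C/c2cc(-c3cc(OC)c(OC)c(OC)c3)n[nH]2)cc1OC`, 78%

All three were tested in a functional assay on A498 cells (Homo sapiens) for cytotoxicity, read by sulforhodamine B assay, with a stated time of 48 h, tested at 1 uM; a higher number here means a weaker effect of the compound at the concentration tested, a lower number a stronger effect. Compound 2 sits at the low end of the three numbers: compound 3 lies within the scatter of it, whereas the number for compound 1 lies beyond the scatter, higher.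

Compound 4 is `COc1cc(-c2cc(/C=C/C(=O)c3ccc(F)c(F)c3)[nH]n2)cc(OC)c1OC` and has not yet been measured in this assay. It differs from compound 2 in one place: 3,4-difluorophenyl in place of 3,4-dichlorophenyl on a carbonyl carbon.

For the measured compounds named here, one measured step bears on this change, since it also swaps the aryl group on the carbonyl carbon of compound 2 while keeping the rest of the molecule: a number 5 percentage points higher from compound 2 to compound 3 (within the scatter). That swap did not move the number beyond the scatter. The change to compound 4 is a smaller one, halogen for halogen on the same ring, so a step of similar or lesser size is expected in this assay, without a direction beyond the scatter. On that basis, compound 4 is expected to give about 75%, estimated to fall between 60% and 92%, a step of a number 2 percentage points higher from compound 2 to compound 4 (within the scatter) from compound 2 that is expected to stay within the scatter.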

Compound 4, a percentage reported as activity, at one concentration (the size of the read-out at that concentration, not a potency): 81%
Beside the measured number, compound 4's estimate is 6 percentage points below it; the range from low to high includes it.
By their numbers in this assay, from the lowest: compounds 2, 3, 4 and 1 (each within the scatter of the next, the first and the last beyond it).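

In this assay the aryl group on the carbonyl carbon now appears in three forms on an otherwise identical molecule, and both new steps, a number 8 percentage points higher from compound 2 to compound 4 (within the scatter) and a number 3 percentage points higher from compound 3 to compound 4 (within the scatter), lie within the scatter. Together with the earlier step, a number 5 percentage points higher from compound 2 to compound 3 (within the scatter), this shows that 3,4-dichlorophenyl, 3,4-difluorophenyl and 3,4-dimethoxyphenyl cannot be told apart at this position at the one concentration tested, and that exchanging one halogen pair for the other leaves compound 4 as close to compound 3 as to compound 2. Nothing given here explains why these three groups read alike.

Because all three groups are phenyl rings with the same substitution pattern, the compounds shown leave open whether a ring carrying a nitrile or a carboxylic acid, or an open alkyl chain in place of the ring, would read differently at this position. They also leave open whether these three compounds would separate at other concentrations, since a single reading at one concentration is not a potency.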